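Swapping Methyl for 4-Methylphenyl on a Sulfonyl Sulfur

A few compounds are considered here, and "the series" means these few. Any claim that something is new, unique, unknown or untested is made for them only; others in the source may bear on it.

- Compound 1 `CCOC1=CC(=O)c2ccccc2C1=O`: 23800 nM
- Compound 2 `CS(=O)(=O)OC1=CC(=O)c2ccccc2C1=O`: 7610 nM

In a functional assay on HeLa cells (Homo sapiens) for cytotoxicity (on this read-out higher numbers stand for weaker inhibition and lower numbers for stronger inhibition), compound 2 gives the lower number of the pair, 7610 nM. Compound 3 `Cc1ccc(S(=O)(=O)OC2=CC(=O)c3ccccc3C2=O)cc1` has 4-methylphenyl in place of methyl on a sulfonyl sulfur. Among the measured compounds shown here, only one measured step bears on this, and only indirectly: a 3.1-fold lower number from compound 1 to compound 2 (0.50 log units; beyond the scatter), a modest step with methylsulfonyl in place of ethyl. For the measured compounds named here, no measured step varies the group on the sulfonyl sulfur, so no step beyond the scatter is expected in this assay. The expected step is a 1.3-fold lower number from compound 2 to compound 3 (0.10 log units; within the scatter). Compound 3 is estimated at 6000 nM, with an expected range of 2000 nM to 18000 nM.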

Compound 3, half-maximal inhibitory concentration: 12200 nM
Estimate against measurement, compound 3: 2.0-fold (0.31 log units) below; measured number inside the range.
By their numbers in this assay, from the lowest: compounds 2, 3 and 1 (each within the scatter of the next, the first and the last beyond it).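

In this assay putting 4-methylphenyl on the sulfonyl sulfur gives a 1.6-fold higher number from compound 2 to compound 3 (0.20 log units; within the scatter) and so does not change the number by more than repeat measurements vary. The earlier pair changed the whole group on the oxygen; this pair shows that, at the sulfonyl sulfur, an aromatic ring can replace a single methyl with no step beyond the scatter. No measurement available here explains this result. As far as these compounds go, whether an amine or a longer chain such as butyl on the sulfonyl sulfur would shift the number remains open.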